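This account rests on a few compounds, and the source may have more. Where it says the series, first, only, none or still open, it means among the compounds named here.

Measured so far in a functional assay on RS4-11 cells (Homo sapiens) for inhibition, read by CCK-8 assay, with a stated time of 72 h (on this read-out lower numbers stand for stronger inhibition and higher numbers for weaker inhibition), are these compounds:
compound 1 `CC1(C)CCC(CN2CCN(c3ccc(C(=O)NS(=O)(=O)c4ccc(NCC5CCOC5)c([N+](=O)[O-])c4)c(Oc4cnc5[nH]ccc5c4)c3)CC2)=C(c2ccc(C(F)(F)F)cc2)C1` gives 24.2 nM
compound 2 `CC1(C)CCC(CN2CCN(c3ccc(C(=O)NS(=O)(=O)c4ccc(NC5CCOC5)c([N+](=O)[O-])c4)c(Oc4cnc5[nH]ccc5c4)c3)CC2)=C(c2ccc(C(F)(F)F)cc2)C1` gives 32 nM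
compound 3 `CC1(C)CCC(CN2CCN(c3ccc(C(=O)NS(=O)(=O)c4ccc(OCC5CCOC5)c([N+](=O)[O-])c4)c(Oc4cnc5[nH]ccc5c4)c3)CC2)=C(c2ccc(C(F)(F)F)cc2)C1` gives 47 nM

Compound 3 (47 nM) lies within the scatter of both other compounds, so these three values cannot be ranked. Compound 4 `CC1(C)CCC(CN2CCN(c3ccc(C(=O)NS(=O)(=O)c4ccc(OCC5CCSCC5)c([N+](=O)[O-])c4)c(Oc4cnc5[nH]ccc5c4)c3)CC2)=C(c2ccc(C(F)(F)F)cc2)C1` is still unmeasured. It carries thian-4-yl in place of oxolan-3-yl on a saturated chain carbon bound to an oxygen on an aromatic ring and is otherwise the same as compound 3.

Going by the values given here, no measured step swaps one ring for another, so the evidence is indirect. Placing oxolan-3-yl in place of (oxolan-3-yl)methyl gave a 1.3-fold higher number from compound 1 to compound 2 (0.12 log units; within the scatter) and was the only change to the chain holding the ring. Placing (oxolan-3-yl)methoxy in place of the matching amino groups gave a 1.9-fold higher number from compound 1 to compound 3 (0.29 log units; within the scatter) and a 1.5-fold higher number from compound 2 to compound 3 (0.17 log units; within the scatter) in the same part of the molecule. All three steps stayed within the scatter, but none of these compounds contains sulfur, so the range should stay wide.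

In this assay no step beyond the scatter is expected. The estimated step is a 1.0-fold lower number from compound 3 to compound 4 (0.02 log units; within the scatter) and could turn out in either direction. Compound 4 is estimated at 45 nM with 18 nM to 110 nM as the expected range.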

Compound 4, half-maximal inhibitory concentration: 15 nM
For compound 4 the middle estimate is 3.0-fold (0.48 log units) above the measured one; measured number outside the range, below it.
By their numbers in this assay, from the lowest: compounds 4, 1, 2 and 3 (each within the scatter of the next, the first and the last beyond it).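

In this assay, going by these compounds alone, replacing oxolan-3-yl with thian-4-yl on a saturated chain carbon bound to an oxygen on an aromatic ring gives a 3.1-fold lower number from compound 3 to compound 4 (0.50 log units; beyond the scatter), the first single-place change here to exceed the scatter, so the ring itself can affect this read-out. Compound 4 also clears the scatter in one further comparison, with a 2.1-fold lower number from compound 2 to compound 4 (0.33 log units; beyond the scatter), but not in the other, with a 1.6-fold lower number from compound 1 to compound 4 (0.21 log units; within the scatter), so it cannot be ranked apart from compound 1. No measurement shown explains the difference between compound 3 and compound 4.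

The change alters ring size and swaps oxygen for sulfur together, so the compounds shown leave open which of the two matters. Oxan-4-yl, a six-membered ring containing oxygen, would separate them, while a (thian-4-yl)methylamino group would show whether the thian-4-yl result carries over to a nitrogen link.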